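Trifluoromethoxy for trifluoromethyl on a pyridazinone amide

The source may report more compounds than this note shows. Statements on the series, on what has been measured and on what is new or still open speak of the compounds shown alone.

Measured compounds:
compound 1 `CNC(=O)c1cc(Oc2ccc(NC(=O)c3nn(-c4ccccc4C(F)(F)F)c(=O)cc3C)cc2F)ccn1` — > 40000 nM
compound 2 `Cc1cc(=O)n(-c2ccccc2OC(F)(F)F)nc1C(=O)Nc1ccc(Oc2ncnc3ccsc23)c(F)c1` — 5720 nM
compound 3 `Cc1cc(=O)n(-c2ccccc2C(F)(F)F)nc1C(=O)Nc1ccc(Oc2ncnc3sccc23)c(F)c1` — 16300 nM

In a functional assay on A549 cells (Homo sapiens) for cytotoxicity, read by MTT assay, with a stated time of 72 h (on this read-out lower numbers stand for stronger inhibition and higher numbers for weaker inhibition), compound 1 gives > 40000 nM, which is a limit of the assay and not a number. Compound 2 gives 5720 nM in this assay. Compound 3 gives 16300 nM in this assay; this is the highest of the two numbers shown, and compound 2 sits a clear distance below it. Among the compounds with values here, the only single-point step measured, an at least 2.4-fold lower number from compound 1 to compound 3 (0.38 log units; beyond the scatter), concerns the group on the aromatic oxygen, not the substituent that changes here.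

Compound 4 `Cc1cc(=O)n(-c2ccccc2OC(F)(F)F)nc1C(=O)Nc1ccc(Oc2ncnc3sccc23)c(F)c1` differs from compound 3 by trifluoromethoxy in place of trifluoromethyl on an aromatic carbon, ortho to a large group. Within the data shown here, no measured step covers this exchange directly. Compound 2 carries trifluoromethoxy as well, but on a different bicyclic oxygen substituent, so its values with compound 3 can only be compared side by side. The expected step of a 2.0-fold lower number from compound 3 to compound 4 (0.31 log units; beyond the scatter) is therefore a modest lowering, leaning on compound 2 at 5720 nM. Compound 4 is estimated at 8000 nM, expected between 3000 nM and 25000 nM.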

Compound 4, half-maximal inhibitory concentration: > 40000 nM
Compound 4: only a limit was reported; the forecaster's own chance of this, stated with the estimate: 10%; at least 5.0-fold (0.69 log units) between middle value and limit.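

In this assay compound 4 gives > 40000 nM, which is a limit of the assay and not a number, the same limit that compound 1 reached: the limit of > 40000 nM in this assay, at which 2 of the 4 values shown sit. With the group on the aromatic oxygen held fixed, trifluoromethoxy in place of trifluoromethyl on the aromatic carbon, ortho to a large group, gives an at least 2.4-fold higher number from compound 3 to compound 4 (0.38 log units; beyond the scatter), so this position does respond to the exchange, and the direction is toward weaker inhibition. Trifluoromethoxy alone does not carry the lower number of compound 2: with it held fixed, changing only the arrangement of the bicyclic group on the aromatic oxygen gives an at least 6.9-fold higher number from compound 2 to compound 4 (0.84 log units; beyond the scatter).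

From the compounds shown here alone, both steps are bounds, so their true size stays open. Also open, going by these compounds, is how a methoxy group or a chlorine atom at this position would read on the same scale.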